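The compounds below may be only part of what the source reports. "The series", "measured", "known", "first", "only" and "open" are said of these compounds alone.

Working notes on the series.

The shared core is carried by compound 1 `COc1ccc(-c2c(C(=O)c3cc(OC)c(OC)c(OC)c3)sc3ccccc23)cc1`, compound 2 `COc1ccccc1-c1c(C(=O)c2cc(OC)c(OC)c(OC)c2)sc2ccccc12` and compound 3 `COc1ccc(-c2c(C(=O)c3cc(OC)c(OC)c(OC)c3)sc3ccccc23)c(OC)c1`. In a functional assay on HL-60 cells (Homo sapiens) for antiproliferative activity, read by MTT assay, with a stated time of 72 h (on this read-out higher numbers stand for weaker inhibition and lower numbers for stronger inhibition), compound 1 gives 1600 nM, the lowest of the three numbers. Compound 2 gives 2900 nM, and a 1.8-fold higher number from compound 1 to compound 2 (0.26 log units; within the scatter). Compound 3 gives 4600 nM, and a 2.9-fold higher number from compound 1 to compound 3 (0.46 log units; beyond the scatter); a 1.6-fold higher number from compound 2 to compound 3 (0.20 log units; within the scatter).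

Compound 4 `COc1cc(C(=O)c2sc3ccccc3c2Nc2ccc(C)cc2)cc(OC)c1OC` has not yet been run in this assay. Its change from compound 1 is (4-methylphenyl)amino in place of 4-methoxyphenyl on an aromatic carbon. The two measured steps from compound 1 both shift a methoxy on the aryl group and leave the aryl-to-core link intact; neither bears directly on an amino-linked ring. All three measured values sit within a modest span of one another, so aryl-side changes have so far moved the number little. Without a measured step of this kind, the direction is open; the expected step of a 1.3-fold higher number from compound 1 to compound 4 (0.10 log units; within the scatter) is set near neutral with a wide range because the closest measured guide is a 2.9-fold higher number from compound 1 to compound 3 (0.46 log units; beyond the scatter). Compound 4 is expected to give about 2000 nM, with a range from 400 nM to 10000 nM.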

Compound 4, half-maximal inhibitory concentration: 4600 nM
The estimate for compound 4 lay 2.3-fold (0.36 log units) below the measured number; the measured number falls inside the stated range.
By their numbers in this assay, from the lowest: compounds 1, 2, 3 and 4 (each within the scatter of the next, the first and the last beyond it).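

For the compounds shown here, at this place on the five-membered aromatic ring, next to the ring atom that bears a large group, (4-methylphenyl)amino in place of 4-methoxyphenyl gives in this assay a first change of the link itself, with a 2.9-fold higher number from compound 1 to compound 4 (0.46 log units; beyond the scatter) as a step beyond the scatter and of modest size. Compound 4 is not set apart from the aryl-linked compounds with a methoxy on the ring's neighbouring carbon, as no change at the digits printed from compound 3 to compound 4 (within the scatter) and a 1.6-fold higher number from compound 2 to compound 4 (0.20 log units; within the scatter) both stay within the scatter, so the amino-linked ring with its added hydrogen-bond donor remains in the same band of numbers as those two and is separated only from compound 1. No measurement bears on why the number takes this value in compound 4.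

Compound 4 changes the link and the ring substituent in one step, so the share of the amino link and the share of the swap from methoxy to methyl stay apart from each other unresolved. Open as well is how this position would answer to (4-methoxyphenyl)amino, to a methyl on the amino nitrogen, or to an ether oxygen or carbonyl as the link.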